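Compound 4: ester cleaved to acid from compound 2

The source may hold more compounds than are shown below. What is called first, only, known or untested is meant among the compounds shown, and "the series" means these compounds.

Measured so far in a functional assay on the whole organism (Tail, strain ICR) with Mus musculus as the target, in the tail flick test, with a stated time of 90 min, at a dose of 25 umol/kg by the oral route; a higher number here means a stronger effect of the compound at the dose given, a lower number a weaker effect:
compound 1 `NCCCC[C@H](NC(=O)CN(c1nc(Cl)nc2[nH]cnc12)C1CC1)C(=O)OCc1ccccc1`, 35.3%;
compound 2 `CC(C)C[C@H](NC(=O)CN(c1nc(Cl)nc2[nH]cnc12)C1CC1)C(=O)OCc1ccccc1`, 15.2%;
compound 3 `CC(C)[C@H](NC(=O)CN(c1nc(Cl)nc2[nH]cnc12)C1CC1)C(=O)OCc1ccccc1`, 51.3%.

Compound 2 stands lowest of the three values: a number 20.1 percentage points lower from compound 1 to compound 2 (beyond the scatter) and a number 36.1 percentage points higher from compound 2 to compound 3 (beyond the scatter), both beyond the scatter, while a number 16 percentage points higher from compound 1 to compound 3 (beyond the scatter). Compound 4 `CC(C)C[C@H](NC(=O)CN(c1nc(Cl)nc2[nH]cnc12)C1CC1)C(=O)O` differs from compound 2 only by the change (hydrogen in place of benzyl on an oxygen next to a carbonyl group). Within the data shown here, no measured step touches this oxygen; all three steps vary the saturated chain carbon bound to the amide-type nitrogen and the carbonyl carbon, so they give no guide to the size or direction of the present step. In this assay no step beyond the scatter is therefore expected, though with a wide range: the estimate means a number 0.2 percentage points lower from compound 2 to compound 4 (within the scatter). Compound 4 is expected to give 15%, between 0% and 40%.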

Compound 4, a percentage reported as activity, at one dose (the size of the read-out at that dose, not a potency): 27%
Beside the measured number, compound 4's estimate is 12 percentage points below it; measured number inside the range.
By their numbers in this assay, from the lowest: compound 2; then compounds 4 and 1 (each within the scatter of the next); then compound 3.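

In this assay, the oxygen next to a carbonyl group proves to be a position that responds to change: hydrogen in place of benzyl gives a number 11.8 percentage points higher from compound 2 to compound 4 (beyond the scatter), so the benzyl group is not required for an effect at this dose. The earlier steps shown here varied only the saturated chain carbon and said nothing about this oxygen. Nothing available accounts for the size or direction of this step.

On these data alone, whether the same change acts alike on compound 1 or compound 3 remains open. As far as these compounds go, how a methyl ester or a primary amide would compare with compound 2 and compound 4 is also open.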